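From cyano to carbamoyl on an aromatic carbon

A few compounds are considered here, and "the series" means these few. Any claim that something is new, unique, unknown or untested is made for them only; others in the source may bear on it.

Values measured in a functional assay (aorta) for inhibition, with Rattus norvegicus as the target (on this read-out lower numbers stand for stronger inhibition and higher numbers for weaker inhibition), are these:
- Compound 1 `C/N=C(\S)[C@]1(c2ccccn2)CCCC[S+]1[O-]` gives > 30000 nM as a limit of the assay, not a number
- Compound 2 `C/N=C(\S)[C@]1(c2cnc(-c3ccccc3)s2)CCCC[S+]1[O-]` gives 4000 nM
- Compound 3 `C/N=C(\S)[C@]1(c2cccc(C#N)c2)CCCC[S+]1[O-]` gives 1600 nM

Of the two actual numbers, compound 3 has the lower one (1600 nM) and compound 2 the higher (4000 nM), a gap beyond the usual scatter. Compound 4 `C/N=C(\S)[C@]1(c2cccc(C(N)=O)c2)CCCC[S+]1[O-]` differs from compound 3 by carbamoyl in place of cyano on an aromatic carbon, meta to a large group (carbamoyl in place of cyano on an aromatic carbon). Among the measured compounds shown here, no measured pair shows this swap, so the expectation is loose. In this assay a moderate step towards weaker inhibition is expected (a 3.1-fold higher number from compound 3 to compound 4 (0.49 log units; beyond the scatter)). Compound 4 is estimated at 5000 nM and is expected to fall between 1500 nM and 20000 nM.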

Compound 4, concentration for 90% inhibition: 12000 nM
The estimate for compound 4 lay 2.4-fold (0.38 log units) below the measured number; low and high end bracket the measured number.
By their numbers in this assay, from the lowest: compound 3; then compound 2; then compound 4. At a limit, above all of these: compound 1.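

In this assay this position on the aromatic ring proves sensitive to the group it carries: carbamoyl in place of cyano gives a 7.5-fold higher number from compound 3 to compound 4 (0.88 log units; beyond the scatter). Among the compounds shown here, this is the first comparison here of two compounds that differ in one place, so the change in inhibition can be tied to that single swap. No measurement shown explains why the step occurs. On these data alone, whether an amine or a carboxylic acid at this position would stay closer to compound 3 remains open, and one pair cannot show whether the swap would act alike on another core.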